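The source may report more compounds than this note shows. Statements on the series, on what has been measured and on what is new or still open speak of the compounds shown alone.

Measured compounds:
- compound 1, `COc1cc(OC)cc(-c2ccc(-c3ccc(C(=N)N)c(F)c3)s2)c1`: 207 nM
- compound 2, `N=C(N)c1ccc(-c2ccc(-c3ccc(Cl)cc3)s2)cc1F`: 156 nM
- compound 3, `N=C(N)c1ccc(-c2ccc(-c3ccc(Cl)cc3)s2)cc1`: 183 nM

All three values come from a functional assay on HCC 2998 cells (Homo sapiens) for inhibition, read by sulforhodamine B assay, with a stated time of 48 h; on this read-out lower numbers stand for stronger inhibition of growth and higher numbers for weaker inhibition of growth. In this assay compound 1 gives 207 nM, compound 2 gives 156 nM and compound 3 gives 183 nM; all three lie within the scatter of one another, so no order among them can be claimed.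

Compounds 2 and 3 differ in one place only: hydrogen in place of fluoro on an aromatic carbon. This change gave a 1.2-fold higher number from compound 2 to compound 3 (0.07 log units; within the scatter), that is, no effect beyond the scatter.

Compound 4, `COc1cc(OC)cc(-c2ccc(-c3ccc(C(=N)N)cc3)s2)c1`, has not yet been measured in this assay. It relates to compound 1 as compound 3 relates to compound 2: hydrogen in place of fluoro on an aromatic carbon. The place described for the two changes is the same word for word, so this is the same change made on a different core; the difference between the core of compound 1 and the core of compound 2 is not broken down here.

Because compound 2 to compound 3 gave a 1.2-fold higher number from compound 2 to compound 3 (0.07 log units; within the scatter), the expectation for compound 1 to compound 4 is a step of similar size, a 1.2-fold higher number from compound 1 to compound 4 (0.06 log units; within the scatter), resting on that single precedent and on compound 1 at 207 nM. Compound 4 is therefore estimated at 240 nM in this assay, with the expected range from 120 nM to 480 nM.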

Compound 4, concentration for 50% growth inhibition: 1820 nM
Compound 4: the middle estimate sits 7.6-fold (0.88 log units) below what was measured, and the stated range ends below it.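

In this assay, hydrogen in place of fluoro on the core of compound 1 weakens growth inhibition, with an 8.8-fold higher number from compound 1 to compound 4 (0.94 log units; beyond the scatter), so on this core the fluoro cannot be dropped without loss. The change therefore does not carry over from one core to the other at a constant size, and a step read on the core of compound 2 is a poor guide to the same step on the core of compound 1: the same change on two cores in this assay, a 1.2-fold higher number (0.07 log units; within the scatter) from compound 2 to compound 3 and an 8.8-fold higher number (0.94 log units; beyond the scatter) from compound 1 to compound 4, 7.5-fold (0.87 log units) apart, beyond the scatter of two such steps. This shows that the size of the step depends on the core in these two pairs, but with a single pair on each core it does not show which part of the core difference matters, why the steps differ, or whether either step is typical of further cores.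

The compounds shown leave open whether the step on the core of compound 1 is specific to fluoro or would also appear with another group on that aromatic carbon, such as a methyl group, a hydroxyl group or a nitrile. They also leave open how the step behaves on cores lying between these two, for example with a single methoxy group in place of the two on compound 1.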